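Swapping the Drawn Configuration at the Ring Carbon

This account rests on a few compounds, and the source may have more. Where it says the series, first, only, none or still open, it means among the compounds named here.

Compound 1, `COc1cc2ncc(O[C@H]3CC4CCC3C4)nc2cc1OC`: 395 nM
Compound 2, `COc1cc2ncc(N[C@@H]3CC4CCC3C4)nc2cc1OC`: 61 nM

For the measured compounds named here, in a functional assay on HASMC cells (Homo sapiens) for inhibition (a lower number here means a stronger inhibitor, a higher number a weaker inhibitor), compound 2 gives the lower of the two numbers measured so far; compound 1 gives a higher number, a gap beyond the usual scatter. Compound 3, `COc1cc2ncc(N[C@H]3CC4CCC3C4)nc2cc1OC`, differs from compound 2 in one respect only: the two compounds have the same atoms and bonds; at least one stereo element is drawn with a configuration in one of them and without one in the other: 1 of 3 stereo elements differ; a stereocentre at a saturated ring carbon is drawn R in compound 2 and S in compound 3. Going by the values given here, no measured pair shows how such a change in drawn configuration plays out in this assay, so the direction is open. Compound 3 is expected to give 150 nM, within 40 nM to 600 nM. That estimate means a step from compound 2 to compound 3 of a 2.5-fold higher number from compound 2 to compound 3 (0.39 log units; beyond the scatter), expected to be modest.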

Compound 3, half-maximal inhibitory concentration: 585 nM
Beside the measured number, compound 3's estimate is 3.9-fold (0.59 log units) below it; the range from low to high includes it.
By their numbers in this assay, from the lowest: compound 2; then compounds 1 and 3 (each within the scatter of the next).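

In this assay the drawn configuration at this ring carbon clearly counts: with atoms and bonds unchanged, the change gives a 9.6-fold higher number from compound 2 to compound 3 (0.98 log units; beyond the scatter) and is well beyond the usual scatter. For the compounds shown here, the earlier compounds held no such pair, so this is the first sign that the spatial arrangement at this one carbon can move the number, with the R drawing the stronger inhibitor. One caution applies to this reading: the fact that one of compounds 2 and 3 is drawn with a defined configuration and the other without, at the place where they differ.

From the compounds shown here alone, it remains open whether the same preference would hold with a methyl group on the amine nitrogen, or with a longer chain in place of the ring.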